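Dropping the ring methyl of compound 3

The source may report more compounds than this note shows. Statements on the series, on what has been measured and on what is new or still open speak of the compounds shown alone.

In a functional assay on A549 cells (Homo sapiens) for cytotoxicity, read by MTT assay, with a stated time of 72 h (on this read-out lower numbers stand for stronger inhibition and higher numbers for weaker inhibition), compound 1 (`COC(=O)c1sc2cc(OC)ccc2c1Nc1cc(OC)c(OC)c(OC)c1`) gives 8.5 nM, compound 2 (`COC(=O)c1sc2cc(C)ccc2c1Nc1cc(OC)c(OC)c(OC)c1`) gives 10.8 nM and compound 3 (`COC(=O)c1sc2nc(C)ccc2c1Nc1cc(OC)c(OC)c(OC)c1`) gives 16.2 nM. Compound 3 thus lies within the scatter of both others. Compound 4 (`COC(=O)c1sc2ncccc2c1Nc1cc(OC)c(OC)c(OC)c1`) is the next case: hydrogen in place of methyl on an aromatic carbon, next to the ring nitrogen. Among the measured compounds shown here, the only measured single-place step, a 1.3-fold higher number from compound 1 to compound 2 (0.10 log units; within the scatter), stays within the scatter. It concerns methyl in place of methoxy, so it bears only loosely on this change. No shift beyond the scatter is expected in this assay. The expected step is a 1.4-fold higher number from compound 3 to compound 4 (0.13 log units; within the scatter). For compound 4 the estimated value is 22 nM, with an expected range of 7 nM to 70 nM.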

Compound 4, half-maximal inhibitory concentration: 3850 nM
Compound 4: the middle estimate sits 180-fold (2.24 log units) below what was measured; measured number above the stated range.
By their numbers in this assay, from the lowest: compounds 1, 2 and 3 (each within the scatter of the next); then compound 4.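

In this assay, hydrogen in place of methyl on an aromatic carbon, next to the ring nitrogen, gives a 240-fold higher number from compound 3 to compound 4 (2.38 log units; beyond the scatter) and so marks this position as highly sensitive: removing one heavy atom is enough to lose most of the activity. The earlier compounds shown here showed only a step within the scatter, at a different exchange, and gave no sign of this. No evidence at hand bears on the reason for the loss.

On these data alone, whether activity requires methyl itself or any group at this carbon stays open; an ethyl group, a chlorine atom or an amine there would separate the two. As far as these compounds go, whether the same removal costs as much on the core of compound 2 is also open.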